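Cyclopropyl quinolone series: N-substituent changes and Vero cytotoxicity

The compounds below may be only part of what the source reports. "The series", "measured", "known", "first", "only" and "open" are said of these compounds alone.

Measured so far:
compound 1 `COc1c(N2CCN(CCC#N)C(C)C2)c(F)cc2c(=O)c(C(=O)O)cn(C3CC3)c12`: 500 ug/mL
compound 2 `COc1c(N2CCN(CCC(C)=O)C(C)C2)c(F)cc2c(=O)c(C(=O)O)cn(C3CC3)c12`: 9.84 ug/mL

In an ADME assay on Vero cells (Chlorocebus sabaeus) for cytotoxicity, read by MTT assay, with a stated time of 72 h (a higher number here means that more compound is tolerated, a lower number that less compound is tolerated), compound 2 gives the lowest of the two numbers; compound 1 sits well apart, with a 51-fold lower number from compound 1 to compound 2 (1.71 log units; beyond the scatter) marking a large drop in tolerated concentration. Compound 3 `COc1c(N2CCN(O)C(C)C2)c(F)cc2c(=O)c(C(=O)O)cn(C3CC3)c12` is not yet measured. The change is hydroxy in place of 2-acetylethyl on an amine nitrogen in a ring. Among the compounds with values here, only the step from compound 1 to compound 2 touches the same amine nitrogen, and it was large, so a large move is possible in either direction. A hydroxy group here is a new kind of substituent for the series, so the expectation leans back toward the higher region but with wide uncertainty. Compound 3 is expected at 100 ug/mL (range 15 ug/mL to 500 ug/mL), an expected step of a 10-fold higher number from compound 2 to compound 3 (1.01 log units; beyond the scatter).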

Compound 3, half-maximal cytotoxic concentration: 19.7 ug/mL
Compound 3: the middle estimate sits 5.1-fold (0.71 log units) above what was measured; the measured number falls inside the stated range.
By their numbers in this assay, from the lowest: compounds 2 and 3 (each within the scatter of the next); then compound 1.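

In this assay the amine nitrogen in a ring tolerates an exchange of 2-acetylethyl for hydroxy, 5 heavy atoms for 1, without a move beyond the scatter (a 2.0-fold higher number from compound 2 to compound 3 (0.30 log units; within the scatter)). The 2-cyanoethyl group of compound 1 stays apart from hydroxy as well (a 25-fold lower number from compound 1 to compound 3 (1.40 log units; beyond the scatter)), so among these three compounds only compound 1 holds the high number. No evidence on the cause is available.

Open, from the compounds shown here alone, is whether a simple methyl group or a longer chain ending in an amine on this nitrogen would fall with compound 1 or with compound 2 and compound 3.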